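This account rests on a few compounds, and the source may have more. Where it says the series, first, only, none or still open, it means among the compounds named here.

Of the compounds shown here, three sharing one core have been measured in a functional assay on 143B cells (Homo sapiens) for antiproliferative activity, read by MTT assay, with a stated time of 48 h; a higher number here means a weaker inhibitor, a lower number a stronger inhibitor. Compound 1 `O=C(Nc1cccc(/C=C/C(=O)c2nc3ccccc3[nH]2)c1)c1ccc(Cl)cc1` gives 7440 nM there. Compound 2 `Cc1cccc(C(=O)Nc2cccc(/C=C/C(=O)c3nc4ccccc4[nH]3)c2)c1` gives 4880 nM in this assay, and compound 3 `Cc1ccc(C(=O)Nc2cccc(/C=C/C(=O)c3nc4ccccc4[nH]3)c2)cc1` gives 6560 nM. Compound 2 holds the lowest of the three numbers, yet its steps to the others are small: a 1.5-fold lower number from compound 1 to compound 2 (0.18 log units; within the scatter) and a 1.3-fold higher number from compound 2 to compound 3 (0.13 log units; within the scatter), both within the scatter, as is a 1.1-fold lower number from compound 1 to compound 3 (0.05 log units; within the scatter).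

Compound 4 `O=C(/C=C/c1cccc(NS(=O)(=O)c2ccc(Cl)cc2)c1)c1nc2ccccc2[nH]1` is not yet measured. It differs from compound 2 by a single change, ((4-chlorophenyl)sulfonyl in place of (3-methylphenyl)carbonyl on a nitrogen on an aromatic ring). Within the data shown here, the measured steps all concern the choice of chloro or methyl on the phenyl ring and leave the carbonyl in place; none of them swaps the carbonyl for a sulfonyl, so that part of the change has no precedent here. Given that every recorded step stayed within the scatter, no movement beyond the scatter is expected in this assay, and the estimated step is a 1.2-fold higher number from compound 2 to compound 4 (0.09 log units; within the scatter). Compound 4 is therefore expected to give about 6000 nM in this assay, with a range from 2500 nM to 15000 nM.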

Compound 4, half-maximal inhibitory concentration: 7450 nM
For compound 4 the middle estimate is 1.2-fold (0.09 log units) below the measured one; measured number inside the range.
By their numbers in this assay, from the lowest: compounds 2, 3, 1 and 4 (each within the scatter of the next).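

Among these compounds, replacing the carbonyl with a sulfonyl on this nitrogen, a change none of the earlier steps covered, stays within the scatter in this assay in all three comparisons: a 1.5-fold higher number from compound 2 to compound 4 (0.18 log units; within the scatter), a 1.1-fold higher number from compound 3 to compound 4 (0.06 log units; within the scatter) and a 1.0-fold higher number from compound 1 to compound 4 (0.00 log units; within the scatter). The last of these is the most direct test, since (4-chlorophenyl)carbonyl and (4-chlorophenyl)sulfonyl carry the same 4-chlorophenyl ring and differ only in the carbonyl or sulfonyl link. No measurement is available that explains this result.

From the compounds shown here alone, all four compounds keep an aryl ring on this link, so the effect of a small acetyl group, a longer alkyl chain or a carboxylic acid there remains open. Going by these compounds, it is also open whether any group at this position can move the number beyond the scatter.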